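Replacing Methylamino with 1-Methoxy-1-methylethyl on the Aromatic Carbon

This account rests on a few compounds, and the source may have more. Where it says the series, first, only, none or still open, it means among the compounds named here.

Compound 1 `C[C@H](NC(=O)c1cc(C(F)(F)F)nn1C)c1nc(-c2ccnc(N(C)C)c2)no1`: 454 nM
Compound 2 `CNc1cc(-c2noc([C@H](C)NC(=O)c3cc(C(F)(F)F)nn3C)n2)ccn1`: 195 nM

Of the compounds shown here, two have been measured in an assay on T-REx-293 cells for inhibition of potassium channel subfamily T member 1 (Homo sapiens), read by patch clamp; a lower number here means a stronger inhibitor, a higher number a weaker inhibitor. Compound 1 gives 454 nM, and compound 2 gives 195 nM. Among the measured compounds shown here, the one measured step is a 2.3-fold lower number from compound 1 to compound 2 (0.37 log units; beyond the scatter). For the measured compounds named here, compound 2 therefore stands lowest of the two numbers, with compound 1 as its only neighbour.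

Compound 3 `COC(C)(C)c1cc(-c2noc([C@H](C)NC(=O)c3cc(C(F)(F)F)nn3C)n2)ccn1` differs from compound 2 in one place: 1-methoxy-1-methylethyl in place of methylamino on an aromatic carbon. The step from compound 1 to compound 2 bears on this change only loosely, since it concerned a substituent on the same nitrogen that is now removed along with the whole methylamino group, and it was modest. Compound 3 gives up the hydrogen-bond donor that compound 2 carries and brings in a larger group with no donor. Nothing measured tells how that larger group will behave, so the expectation for compound 3 is a weaker number than compound 2, roughly back toward compound 1, with wide uncertainty: an expected 3.1-fold higher number from compound 2 to compound 3 (0.49 log units; beyond the scatter), which means compound 3 is estimated at 600 nM, within 200 nM to 1800 nM.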

Compound 3, half-maximal inhibitory concentration in the potassium channel subfamily T member 1 assay: 6280 nM
Compound 3: the middle estimate sits 10-fold (1.02 log units) below what was measured; the measured number lies above the stated range.
By their numbers in the potassium channel subfamily T member 1 assay, from the lowest: compound 2; then compound 1; then compound 3.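

This aromatic carbon next to the ring nitrogen tolerates far less than the modest step between the two amines had shown: in the potassium channel subfamily T member 1 assay, putting 1-methoxy-1-methylethyl in place of methylamino gives a 32-fold higher number from compound 2 to compound 3 (1.51 log units; beyond the scatter). Set against dimethylamino the exchange is also large, with a 14-fold higher number from compound 1 to compound 3 (1.14 log units; beyond the scatter), and since compound 1 lacks the amine hydrogen of compound 2 as well, the loss of that hydrogen alone does not account for the drop. The same exchange also shifts the measured lipophilicity in a physicochemical assay for lipophilicity (a lower number here means a more polar compound, a higher number a more lipophilic compound), where compound 2 gives 3.4 and compound 3 gives 3.8: the measured distribution coefficient of compound 2, 3.4, and of compound 3, 3.8, a number 0.40 log units higher (beyond the scatter)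

With a single pair, the compounds shown cannot tell whether that rise in lipophilicity has any share in the loss, or whether the loss follows from the size of the new group, its ether oxygen or its two methyl groups. A primary amine, a methoxy group or a plain ethyl chain on this same carbon would help separate these possibilities, and none of them stands among the compounds shown here.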